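Shortening a Carboxyalkyl Chain on a Shared Core

This account rests on a few compounds, and the source may have more. Where it says the series, first, only, none or still open, it means among the compounds named here.

Four compounds share one core and differ only in a small acid-bearing side chain. In an ADME assay on the whole organism (Mus musculus, strain CD1) for pharmacokinetics, read by LC-MS, with a stated time of 24 h, at a dose of 1 mg/kg by the intravenous route (on this read-out higher numbers stand for wider distribution into tissues and lower numbers for narrower distribution), compound 1 `CCC(C(=O)O)c1nn(Cc2cn3cc(OCC4CC4)c(Cl)cc3n2)c2ccccc2c1=O` gives 0.78 L/kg. Compound 2 `C[C@H](C(=O)O)n1nc(Cn2cc3cc(OCC4CC4)c(Cl)cc3n2)c2ccccc2c1=O` gives 1.9 L/kg, and compound 3 `O=C(O)Cn1nc(Cc2cn3cc(OCC4CC4)c(Cl)cc3n2)c2ccccc2c1=O` gives 0.28 L/kg, so compound 1 sits between them, with both gaps wider than the usual scatter. Compound 4 `C[C@H](C(=O)O)c1nn(Cc2cn3cc(OCC4CC4)c(Cl)cc3n2)c2ccccc2c1=O` has not yet been measured in this assay. It differs from compound 1 by 1-carboxyethyl in place of 1-carboxypropyl on an aromatic carbon. Among the measured compounds shown here, no measured pair shows exactly this change, so the step from compound 1 to compound 4 is expected to be small, likely within the scatter, as a 1.1-fold lower number from compound 1 to compound 4 (0.05 log units; within the scatter). Compound 4 is therefore estimated at 0.7 L/kg, within a range from 0.35 L/kg to 1.4 L/kg.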

Compound 4, volume of distribution at steady state: 0.56 L/kg
For compound 4 the middle estimate is 1.3-fold (0.10 log units) above the measured one, within the range that was stated.
By their numbers in this assay, from the lowest: compounds 3, 4 and 1 (each within the scatter of the next, the first and the last beyond it); then compound 2.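

On this aromatic carbon, putting 1-carboxyethyl in place of 1-carboxypropyl gives a 1.4-fold lower number from compound 1 to compound 4 (0.14 log units; within the scatter) in this assay, so this side chain can lose one carbon without a shift beyond the usual scatter. Among the compounds shown here, this pair is the only direct reading of the change, and the entering group also brings a defined stereocentre, so the two differences cannot be separated here. No measurement shown explains the size of this step. Going by these compounds, what a longer chain, or an amide in place of the carboxylic acid, would do on this carbon remains open.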